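A few compounds are considered here, and "the series" means these few. Any claim that something is new, unique, unknown or untested is made for them only; others in the source may bear on it.

Measured compounds: compound 2 `O=C(CSc1nc2c(c(=O)n1-c1ccccc1)SCC2)Nc1ccc(-c2cccnc2)cc1` with 0.45 nM in an assay on L cells for inhibition of Protein-serine O-palmitoleoyltransferase porcupine (Mus musculus), read by reporter gene assay, with a stated time of 24 h; a higher number here means that more compound is needed for the effect, a lower number that less compound is needed; compound 1 `CCOc1ccc(NC(=O)CSc2nc3c(c(=O)n2-c2ccccc2)SCC3)cc1` with 1000 nM; compound 3 `COc1ccc(-n2nc(C(=O)NCC(=O)Nc3nc4ccc(OC)cc4s3)c3ccccc3c2=O)cc1` with 60 nM.

Compound 2 gives the lowest number of the three in this assay; compound 3 comes nearest and compound 1 lies furthest away. Compound 4 `O=C(CSc1nc2c(c(=O)n1-c1ccccc1)SCC2)Nc1ccc(-c2ccccc2)cc1` differs from compound 2 by phenyl in place of pyridin-3-yl on an aromatic carbon. For the measured compounds named here, no measured pair shows this exact exchange. Going by the values given here, the one step at the same place, a 2200-fold lower number from compound 1 to compound 2 (3.35 log units; beyond the scatter), shows that what sits there can move the number by a large amount. Since nothing measured shows a phenyl there, compound 4 is expected to keep most of the potency of compound 2 but lose some, an estimated step of a 6.7-fold higher number from compound 2 to compound 4 (0.82 log units; beyond the scatter). The estimate for compound 4 is 3 nM, ranging from 0.6 nM to 15 nM.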

Compound 4, half-maximal effective concentration: 0.75 nM
For compound 4 the middle estimate is 4.0-fold (0.60 log units) above the measured one; low and high end bracket the measured number.
By their numbers in this assay, from the lowest: compounds 2 and 4 (each within the scatter of the next); then compound 3; then compound 1.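

In this assay phenyl and pyridin-3-yl cannot be told apart at this place, with a 1.7-fold higher number from compound 2 to compound 4 (0.22 log units; within the scatter), so the ring nitrogen is not required for a low number. The large distance from the ethoxy compound also holds for an aromatic ring of carbon only, with a 1300-fold lower number from compound 1 to compound 4 (3.12 log units; beyond the scatter), and so is not tied to pyridin-3-yl. Nothing given here explains that distance. Still open, from the compounds shown here alone, is whether a non-aromatic ring such as piperidine, or a single chlorine atom, would serve at this place as well as these two aromatic rings.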